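Aryl Exchange at the Saturated Ring Carbon of Compound 3

The source may report more compounds than this note shows. Statements on the series, on what has been measured and on what is new or still open speak of the compounds shown alone.

Compound 1 `COc1ccc(C2OC(c3cc(OC)c(OC)c(OC)c3)=NN2C(C)=O)c(OC)c1` gives 6.3% in a functional assay on BGC-823 cells (Homo sapiens) for antiproliferative activity, read by MTT assay, tested at 1 uM; a higher number here means a stronger effect of the compound at the concentration tested, a lower number a weaker effect.
Compound 2 `COc1cc(C2=NN(C(C)=O)C(c3ccccc3F)O2)cc(OC)c1OC` gives 29.6% in this assay.
Compound 3 `COc1ccc(OC)c(C2OC(c3cc(OC)c(OC)c(OC)c3)=NN2C(C)=O)c1` gives 0.4% in this assay.

Compound 3 holds the lowest of the three numbers in this assay. Compound 1 lies nearest to it, with a number 5.9 percentage points lower from compound 1 to compound 3 (within the scatter), while compound 2 lies furthest, with a number 29.2 percentage points lower from compound 2 to compound 3 (beyond the scatter). Compound 4 `COc1cc(C2=NN(C(C)=O)C(c3ccc(C(F)(F)F)cc3)O2)cc(OC)c1OC` has not yet been measured. It differs from compound 3 in one place: 4-(trifluoromethyl)phenyl in place of 2,5-dimethoxyphenyl on a saturated ring carbon.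

For the measured compounds named here, two measured steps bear on this exchange. Both a number 23.3 percentage points higher from compound 1 to compound 2 (beyond the scatter) and a number 29.2 percentage points lower from compound 2 to compound 3 (beyond the scatter) involved swapping a dimethoxyphenyl for a fluorine-bearing phenyl on the same saturated ring carbon, and both were beyond the scatter, with the fluorine-bearing phenyl on the higher side. The step of a number 5.9 percentage points lower from compound 1 to compound 3 (within the scatter), between two dimethoxyphenyls, stayed within the scatter. The move to compound 4 is therefore expected to be an upward step beyond the scatter, a number 21.6 percentage points higher from compound 3 to compound 4 (beyond the scatter). Compound 4 is estimated at 22% in this assay, with a range from 4% to 42%.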

Compound 4, a percentage reported as inhibition, at one concentration (the size of the read-out at that concentration, not a potency): 4.2%
Estimate against measurement, compound 4: 17.8 percentage points above; the measured number falls inside the stated range.
By their numbers in this assay, from the lowest: compounds 3, 4 and 1 (each within the scatter of the next); then compound 2.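

In this assay, a fluorine-bearing phenyl on this saturated ring carbon does not by itself go with a higher number: the 4-(trifluoromethyl)phenyl stays within the scatter of both dimethoxyphenyls (a number 3.8 percentage points higher from compound 3 to compound 4 (within the scatter)) (a number 2.1 percentage points lower from compound 1 to compound 4 (within the scatter)) and falls short of the 2-fluorophenyl (a number 25.4 percentage points lower from compound 2 to compound 4 (beyond the scatter)). The earlier link between fluorine and a higher number therefore rests on compound 2 alone, and compound 4 goes against it. Nothing given here accounts for this difference between the two fluorine-bearing groups.

The 2-fluorophenyl and the 4-(trifluoromethyl)phenyl differ both in the substituent and in where it sits on the phenyl, so these compounds cannot separate the two. From the compounds shown here alone, how a 4-fluorophenyl, a 2-(trifluoromethyl)phenyl, or a phenyl bearing an amine or a carboxylic acid would read at this carbon remains open.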